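Bromo in place of phenyl: working notes on compound 4

The compounds below may be only part of what the source reports. "The series", "measured", "known", "first", "only" and "open" are said of these compounds alone.

Three compounds carry numbers in a functional assay on HPAC cells (Homo sapiens) for inhibition, read by MTT assay, with a stated time of 72 h; a lower number here means a stronger inhibitor of growth, a higher number a weaker inhibitor of growth. Compound 1 `O=S(=O)(NCCCCNCc1ccc(Br)cc1)c1cc(C(F)(F)F)cc(C(F)(F)F)c1` gives 2000 nM. Compound 2 `COc1ccc(CNCCCNS(=O)(=O)c2cc(C(F)(F)F)cc(C(F)(F)F)c2)cc1OC` gives 3500 nM. Compound 3 `O=S(=O)(NCCCNCc1ccc(-c2ccccc2)cc1)c1cc(C(F)(F)F)cc(C(F)(F)F)c1` gives 2700 nM, the second highest of the three; compound 2 sits nearest and compound 1 furthest, both within the usual scatter, so the three numbers cannot be set in order. Within the data shown here, no two measured compounds differ in a single place, so no measured step is known. Compound 4 `O=S(=O)(NCCCNCc1ccc(Br)cc1)c1cc(C(F)(F)F)cc(C(F)(F)F)c1` differs from compound 3 by bromo in place of phenyl on an aromatic carbon. Compound 1 also carries the bromo and in this assay compound 1 gives 2000 nM, close to compound 3. The step of a 1.1-fold lower number from compound 3 to compound 4 (0.03 log units; within the scatter) is therefore expected to be none beyond the scatter. Compound 4 is estimated at 2500 nM, between 1200 nM and 5500 nM.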

Compound 4, concentration for 50% growth inhibition: 2900 nM
The estimate for compound 4 lay 1.2-fold (0.06 log units) below the measured number; the measured number falls inside the stated range.
By their numbers in this assay, from the lowest: compounds 1, 3, 4 and 2 (each within the scatter of the next).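

In this assay bromo in place of phenyl on the aromatic carbon, para to a large group, leaves the number within the scatter (a 1.1-fold higher number from compound 3 to compound 4 (0.03 log units; within the scatter)). The same holds for 4-bromophenyl in place of 3,4-dimethoxyphenyl (a 1.2-fold lower number from compound 2 to compound 4 (0.08 log units; within the scatter)) and for (4-bromobenzyl)amino in place of ((4-bromobenzyl)amino)methyl (a 1.5-fold higher number from compound 1 to compound 4 (0.16 log units; within the scatter)). A single bromine atom and a six-carbon phenyl ring are thus not told apart at this position, and no measurement available here offers an explanation. Open, from the compounds shown here alone, is whether an amine or a carboxylic acid at this position would give a step beyond the scatter. Open too, going by these compounds, is whether a longer chain would do so.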